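Replacement of the naphthalen-1-yl group on the saturated ring carbon

The source may hold more compounds than are shown below. What is called first, only, known or untested is meant among the compounds shown, and "the series" means these compounds.

Compound 1 `N#CC1=C(N)OC(c2c[nH]c3ccccc23)=C(C#N)C1c1cccc2ccccc12` carries a naphthalen-1-yl group on a saturated ring carbon of the shared core. Among the compounds with values here, in a functional assay, tested at 200 ug/mL (a higher number here means a stronger effect of the compound at the concentration tested, a lower number a weaker effect), compound 1 gives 7.7%, the lowest of the two numbers measured so far. Compound 2 `N#CC1=C(N)OC(c2c[nH]c3ccccc23)=C(C#N)C1c1ccccc1`, with phenyl in that place, gives 24.5% in this assay, so that a number 16.8 percentage points higher from compound 1 to compound 2 (beyond the scatter). Compound 3 `CN(C)c1ccc(C2C(C#N)=C(N)OC(c3c[nH]c4ccccc34)=C2C#N)cc1` is not yet measured; its change from compound 1 is 4-(dimethylamino)phenyl in place of naphthalen-1-yl on a saturated ring carbon. Within the data shown here, only the step from compound 1 to compound 2 bears on it: both exchange naphthalen-1-yl for a group with one six-membered aromatic ring of carbon only. A rise of similar size is therefore expected, a number 14.3 percentage points higher from compound 1 to compound 3 (beyond the scatter). Compound 3 is estimated at 22%, within 8% to 38%.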

Compound 3, a percentage reported as activity, at one concentration (the size of the read-out at that concentration, not a potency): 20.5%
The estimate for compound 3 lay 1.5 percentage points above the measured number; the range from low to high includes it.
By their numbers in this assay, from the lowest: compound 1; then compounds 3 and 2 (each within the scatter of the next).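

In this assay there is a number 12.8 percentage points higher from compound 1 to compound 3 (beyond the scatter), so a second group with one six-membered aromatic ring of carbon only, in place of naphthalen-1-yl on the saturated ring carbon, moves the number the same way. On the phenyl ring, dimethylamino in place of hydrogen on an aromatic carbon gives a number 4 percentage points lower from compound 2 to compound 3 (within the scatter), so no effect of this exchange can be read. Nothing measured explains either step.

As far as these compounds go, whether methyl or cyclohexyl on the saturated ring carbon would keep the number of compound 2 stays open. So does whether a carboxylic acid on the phenyl ring would move the number beyond the scatter.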